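This account rests on a few compounds, and the source may have more. Where it says the series, first, only, none or still open, it means among the compounds named here.

Two compounds sharing one core have been examined so far, and neither yields a number. Compound 1 `COc1ccc(-c2cn(C(=O)Nc3cc(OC)c(OC)c(OC)c3)c(=O)n2-c2cc(OC)c(OC)c(OC)c2)cc1O` stands as "not determined" (no result reported) in a functional assay on MCF7 cells (Homo sapiens) for cytotoxicity, read by MTT assay, with a stated time of 48 h (a lower number here means a stronger inhibitor, a higher number a weaker inhibitor), so it offers no guidance on the scale. Compound 2 `COc1cc(-n2c(-c3ccccc3)cn(C(C)=O)c2=O)cc(OC)c1OC`, which carries an unsubstituted phenyl, gives > 50000 nM in this assay. This value is a limit of the assay and not a number.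

The next compound to be tested is compound 3 `COc1ccc(-c2cn(C(C)=O)c(=O)n2-c2cc(OC)c(OC)c(OC)c2)cc1`. It departs from compound 2 at a single place, where phenyl becomes 4-methoxyphenyl: methoxy in place of hydrogen on an aromatic carbon. In words, methoxy stands in place of hydrogen on an aromatic carbon, para to a large group.

Among the measured compounds shown here, no step between measured compounds is available, so any expectation rests on this one structural change and remains loose. The expected step of an at least 5.0-fold lower number from compound 2 to compound 3 (0.69 log units; beyond the scatter) in this assay points toward a stronger inhibitor, though its size is highly uncertain, and a further reading at the limit would not be surprising. Compound 3 is estimated at 10000 nM. The expected range for compound 3 runs from 500 nM to 60000 nM.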

Compound 3, half-maximal inhibitory concentration: > 50000 nM
Compound 3: a limit, no number; the forecaster's own chance of this, stated with the estimate: 40%; at least 5.0-fold (0.69 log units) between middle value and limit.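

Compound 3, like compound 2, rests at a limit in this assay and not at a number, so no step can be read between compound 2 and compound 3 because both sit at the same limit: the limit of > 50000 nM in this assay, at which 2 of the 3 values shown sit. The compounds shown leave open whether methoxy in place of hydrogen on an aromatic carbon changes the reading at all.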